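This account rests on a few compounds, and the source may have more. Where it says the series, first, only, none or still open, it means among the compounds named here.

Compound 1 `COc1ccc(Cl)cc1N1CCN(C(=O)c2oc(C)nc2-c2ccccc2F)CC1` gives 153 nM in a functional assay on HL-60 cells (Homo sapiens) for inhibition, read by MTT assay, with a stated time of 72 h; a lower number here means a stronger inhibitor, a higher number a weaker inhibitor.
Compound 2 `Cc1nc(-c2ccccc2)c(C(=O)N2CCN(c3ccccc3Cl)CC2)o1` gives 124 nM in this assay.

Of the two numbers, compound 2 has the lower one, but compound 1 sits so close to it that the gap lies within the usual scatter, so no order between the two can be read from these measurements. Both share the same core and differ only in the group on the ring amine nitrogen.

Compound 3 `Cc1nc(-c2ccccc2)c(C(=O)N2CCN(c3ccc(C)c(C)c3)CC2)o1` has not yet been measured in this assay. It differs from compound 2 in one place: 3,4-dimethylphenyl in place of 2-chlorophenyl on an amine nitrogen in a ring. Within the data shown here, no pair of measured compounds shows what this kind of exchange does, so the direction of the step is open. The step from compound 2 to compound 3 is expected to be small, a 2.0-fold higher number from compound 2 to compound 3 (0.30 log units; within the scatter), leaning toward a higher number. For compound 3 the estimate is 250 nM, with a range from 80 nM to 800 nM.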

Compound 3, half-maximal inhibitory concentration: 43 nM
Compound 3: middle estimate off by 5.8-fold (0.76 log units), on the high side; the whole stated range lies above it.
By their numbers in this assay, from the lowest: compound 3; then compounds 2 and 1 (each within the scatter of the next).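

In this assay, among these compounds, the exchange of 2-chlorophenyl for 3,4-dimethylphenyl on the ring amine nitrogen gives a 2.9-fold lower number from compound 2 to compound 3 (0.46 log units; beyond the scatter) and this is the first step to lie beyond the scatter. It shows that the number responds to what this aromatic ring carries, even though both groups are six-membered carbon-only aromatic rings with no hydrogen-bond donors or acceptors and no net charge. No measurement at hand says why the number falls.

Going by these compounds, it remains open whether the step comes from losing the chlorine or from gaining the two methyl groups, since both happen in one exchange. On these data alone, how a trifluoromethyl group or a carboxylic acid on this ring would behave is also open, as is whether the same exchange would give a similar step on the core of compound 1.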